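The compounds below may be only part of what the source reports. "The series", "measured", "known", "first", "only" and "open" are said of these compounds alone.

Compound 1 `COc1ccc(NC(=O)c2c(O)c3cccnc3n(-c3ccccc3)c2=O)cc1`: -1.9%
Compound 2 `Cc1ccccc1NC(=O)c1c(O)c2cccnc2n(-c2ccccc2)c1=O`: 9.8%

In a functional assay on the whole organism for inhibition, with Rattus norvegicus as the target, read by cytopathic effect and paw edema, at a dose of 100 mg/kg by the oral route (a lower number here means less inhibition, a higher number more inhibition at the dose given (going by the name of the read-out)), compound 1 gives -1.9%, the lowest of the two numbers; compound 2 gives 9.8%. Going by the values given here, the only measured step, a number 11.7 percentage points higher from compound 1 to compound 2 (beyond the scatter), also alters the group on the amide-type nitrogen, but in a different way, so it bears on the present change only loosely and shows that this position can move the read-out modestly. Compound 3 `COc1ccc(NC(=O)c2c(O)c3cccnc3n(-c3ccccc3)c2=O)cn1` differs from compound 1 by 6-methoxypyridin-3-yl in place of 4-methoxyphenyl on an amide-type nitrogen. Compound 3 is expected to shift by about a number 4.9 percentage points higher from compound 1 to compound 3 (within the scatter), a step within the scatter. The estimate for compound 3 is 3%, with a range from -10% to 16%.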

Compound 3, a percentage reported as inhibition, in the whole organism at one dose (the size of the read-out at that dose, not a potency): -10.2%
Beside the measured number, compound 3's estimate is 13.2 percentage points above it; measured number outside the range, below it.
By their numbers in this assay, from the lowest: compounds 3 and 1 (each within the scatter of the next); then compound 2.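

In this assay, 6-methoxypyridin-3-yl in place of 4-methoxyphenyl on the amide-type nitrogen gives a number 8.3 percentage points lower from compound 1 to compound 3 (within the scatter) and so does not separate these two groups. Set against 2-methylphenyl, the same group gives a number 20 percentage points lower from compound 2 to compound 3 (beyond the scatter) and thus 2-methylphenyl alone stands apart among the three groups at this position. No measurement at hand explains these numbers. The compounds shown leave open whether an amine or a carboxylic acid on the ring carried by this nitrogen, or a longer chain in place of methoxy, would raise the read-out at this dose.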